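Compound 3 leads the series; benzyl replaces cyclohexyl

The source may hold more compounds than are shown below. What is called first, only, known or untested is meant among the compounds shown, and "the series" means these compounds.

Measured so far in a functional assay on RPMI-8226 cells (Homo sapiens) for inhibition, read by sulforhodamine B assay, with a stated time of 48 h, tested at 10 uM; on this read-out higher numbers stand for more inhibition at the one concentration tested (going by the name of the read-out) and lower numbers for less inhibition:

compound 1 `Brc1cn2ccnc2c(-c2ccc3ncn(C4CCCCC4)c3c2)n1` — 14.9%
compound 2 `c1csc(-c2cn3ccnc3c(-c3ccc4ncn(C5CCCCC5)c4c3)n2)c1` — 52.3%
compound 3 `c1cn2cc(-c3ccc4c(c3)ncn4C3CCCCC3)nc(-c3ccc4ncn(C5CCCCC5)c4c3)c2n1` — 70.8%

Compound 3 stands highest of the three numbers in this assay. Its nearest neighbour is compound 2, a step lower that lies beyond the scatter, and compound 1 is furthest, lower again beyond the scatter. For the measured compounds named here, the only step between two compounds that differ in one place is a number 37.4 percentage points higher from compound 1 to compound 2 (beyond the scatter); it concerns the group on the aromatic carbon, not the group on the aromatic nitrogen.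

Compound 4 `c1ccc(Cn2cnc3ccc(-c4nc(-c5ccc6c(c5)ncn6C5CCCCC5)cn5ccnc45)cc32)cc1` is the next compound to be measured. It differs from compound 3 as follows: benzyl in place of cyclohexyl on an aromatic nitrogen.

Going by the values given here, no measured step touches the group on the aromatic nitrogen; every measured compound carries cyclohexyl there, so the single step on record gives no direct guide to this change. In the absence of such a step, the expectation is that compound 4 stays close to compound 3, with a step of a number 5.8 percentage points lower from compound 3 to compound 4 (within the scatter) that is expected to fall within the scatter. Compound 4 is therefore estimated at 65% in this assay, with a range from 45% to 85%.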

Compound 4, a percentage reported as inhibition, at one concentration (the size of the read-out at that concentration, not a potency): -41.2%
Estimate against measurement, compound 4: 106.2 percentage points above; measured number outside the range, below it.
By their numbers in this assay, from the lowest: compound 4; then compound 1; then compound 2; then compound 3.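

In this assay, for the compounds shown here, the first measured change on the aromatic nitrogen gives a number 112 percentage points lower from compound 3 to compound 4 (beyond the scatter), so this position is far from silent. The exchange is small on paper: benzyl brings 7 heavy atoms where cyclohexyl had 6, a six-membered aromatic ring replaces a non-aromatic one, neither group has hydrogen-bond donors or acceptors, and neither carries a net charge, yet compound 4 reads -41.2%, a negative number unlike those of the three earlier compounds. For this pair, then, inhibition at the one concentration tested depends strongly on the group at this nitrogen, and no measurement shown here explains the loss.

The step does not separate the aromatic ring from the added carbon, and cyclohexylmethyl or phenyl on this nitrogen would pull those two changes apart. Also open, on these data alone, is how a smaller group such as methyl, a longer alkyl chain or a chain ending in an amine would read at this position, and whether benzyl would act in the same way with a different group on the aromatic carbon.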